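Changing the aryl group on the carboxy-bearing ring

The compounds below may be only part of what the source reports. "The series", "measured", "known", "first", "only" and "open" are said of these compounds alone.

Compound 1 `Cc1cc(C#N)cc(-c2c(C)nn(-c3nc(-c4ccc(Cl)c(Cl)c4)c(SC(C)C)s3)c2C(=O)O)c1`: 4800 nM
Compound 2 `Cc1oncc1-c1nc(-n2nc(C(=O)O)c(-c3cc(Cl)cc(Cl)c3)c2C)sc1SC(C)C`: > 44000 nM
Compound 3 `Cc1c(-c2cc(Cl)cc(Cl)c2)c(C(=O)O)nn1-c1nc(-c2cc(Cl)cc(Cl)c2)c(SC(C)C)s1`: 2000 nM

In a functional assay on BJAB cells (Homo sapiens) for antiproliferative activity, with a stated time of 4 days (a lower number here means that less compound is needed, a higher number that more compound is needed for the effect), compound 1 gives 4800 nM, the highest of the two numbers recorded; compound 3 sits lower at 2000 nM. The value of compound 2 is only a limit of the assay, (the limit of > 44000 nM in this assay, at which 1 of the 3 values shown sits). Among the compounds with values here, the single measured step, an at least 22-fold lower number from compound 2 to compound 3 (1.34 log units; beyond the scatter), alters the group on the sulfur-containing ring and so does not bear on the change studied here: 2-methoxy-5-methylphenyl in place of 3-cyano-5-methylphenyl on an aromatic carbon. Within the data shown here, compound 4 `COc1ccc(C)cc1-c1c(C)nn(-c2nc(-c3ccc(Cl)c(Cl)c3)c(SC(C)C)s2)c1C(=O)O` therefore has no close precedent, and the step of a 1.0-fold higher number from compound 1 to compound 4 (0.02 log units; within the scatter) is expected to stay within the scatter. Compound 4 is estimated at 5000 nM, with a range from 1500 nM to 20000 nM.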

Compound 4, half-maximal effective concentration: 9500 nM
For compound 4 the middle estimate is 1.9-fold (0.28 log units) below the measured one, and the stated range covers the measured number.
By their numbers in this assay, from the lowest: compound 3; then compounds 1 and 4 (each within the scatter of the next). At a limit, above all of these: compound 2.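

Putting 2-methoxy-5-methylphenyl in place of 3-cyano-5-methylphenyl, on the aromatic carbon next to the ring atom that bears a carboxy group, gives a 2.0-fold higher number from compound 1 to compound 4 (0.30 log units; within the scatter). Within the data shown here, this is the first measured step at this position with the rest of the molecule unchanged, and it shows that this swap of one substituted phenyl group for another stays within the scatter. Nothing measured here offers a reason for this result.

On these data alone, the nitrile and methoxy groups change together, so their separate contributions remain unknown. As far as these compounds go, a plain phenyl group, or a phenyl ring carrying an amine, also remains open at this position.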